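The source may report more compounds than this note shows. Statements on the series, on what has been measured and on what is new or still open speak of the compounds shown alone.

Measured so far:
Compound 1, `CC(=O)N[C@@H]1CCC[C@H](C(=O)Nc2cc(-c3cnn4c3CCCC4)c(Cl)cn2)C1`, gives 46 uL/min in an ADME assay on cells (Hepatocyte, Rattus norvegicus) for metabolic stability, using equilibrium dialysis; a higher number here means faster removal of the compound, a lower number slower removal.
Compound 2, `CC(=O)N[C@@H]1CCC[C@H](C(=O)Nc2cc(-c3cnn4c3CCCCC4)c(Cl)cn2)C1`, gives 51 uL/min in this assay.

Compound 2 and compound 1 sit close together on these numbers: a 1.1-fold higher number from compound 1 to compound 2 (0.04 log units; within the scatter). Compound 3, `CC(=O)N[C@@H]1CCC[C@H](C(=O)Nc2cc(-c3cnn4c3COCC4)c(Cl)cn2)C1`, differs from compound 2 in one place: a group of 9 heavy atoms (6 carbon, 2 nitrogen, 1 oxygen; one five-membered aromatic ring with 2 hetero atoms, one six-membered non-aromatic ring with 2 hetero atoms) in place of a group of 10 heavy atoms (8 carbon, 2 nitrogen; one five-membered aromatic ring with 2 hetero atoms, one seven-membered non-aromatic ring with 1 hetero atom), on an aromatic carbon. Going by the values given here, the only measured step that touches this part of the molecule is the one from compound 1 to compound 2, where the six-membered non-aromatic ring became a seven-membered one and the number stayed within the scatter. Reshaping that ring once more, now to a six-membered ring with two hetero atoms, is therefore expected to give no step beyond the scatter in this assay; the measured steps say nothing about an oxygen inside the ring. The expected step is a 1.1-fold lower number from compound 2 to compound 3 (0.05 log units; within the scatter). Compound 3 is thus estimated to give 45 uL/min, within a range from 22 uL/min to 90 uL/min.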

Compound 3, intrinsic clearance in a liver preparation (reported as CLH), per the amount of preparation that the assay uses: 18 uL/min
The estimate for compound 3 lay 2.5-fold (0.40 log units) above the measured number; measured number outside the range, below it.
By their numbers in this assay, from the lowest: compound 3; then compounds 1 and 2 (each within the scatter of the next).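

In this assay, this position turns out to respond to a change in the ring's atoms: with the ring size kept, an oxygen in place of one ring carbon gives a clear step (a 2.6-fold lower number from compound 1 to compound 3 (0.41 log units; beyond the scatter)). The comparison with the seven-membered ring points the same way (a 2.8-fold lower number from compound 2 to compound 3 (0.45 log units; beyond the scatter)), whereas going from the six-membered to the seven-membered all-carbon-and-one-nitrogen ring stayed within the scatter (a 1.1-fold higher number from compound 1 to compound 2 (0.04 log units; within the scatter)). Among these three compounds, then, the ring holding the oxygen stands apart and ring size does not, though nothing measured here gives a reason for that.

As far as these compounds go, whether an amine nitrogen or a carbonyl in place of that same ring carbon would lower the number as well remains open. So does whether the oxygen would have the same effect at another place in the ring or inside the seven-membered ring.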